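The source may report more compounds than this note shows. Statements on the series, on what has been measured and on what is new or still open speak of the compounds shown alone.

The measured compounds: compound 1 `COc1cc(-c2cc(/C=C/C(=O)c3ccc(N)cc3)[nH]n2)cc(OC)c1OC` with 1650 nM; compound 2 `COc1ccc(C(=O)/C=C/c2cc(-c3cc(OC)c(OC)c(OC)c3)n[nH]2)cc1OC` with 1650 nM; compound 3 `COc1ccc(-c2cc(/C=C/C(=O)c3ccc(N)cc3)[nH]n2)cc1OC` with 3160 nM.

All three values come from a functional assay on SK-MEL-5 cells (Homo sapiens) for inhibition, read by sulforhodamine B assay, with a stated time of 48 h; a lower number here means a stronger inhibitor of growth, a higher number a weaker inhibitor of growth. Compound 3 and compound 1 differ in one place, (methoxy in place of hydrogen on an aromatic carbon), and the step was a 1.9-fold lower number from compound 3 to compound 1 (0.28 log units; within the scatter). Between compound 1 and compound 2 the step was no change at the digits printed from compound 1 to compound 2 (within the scatter). The difference between the cores of compound 2 and compound 3 is not broken down here. Among the compounds with values here, compound 4 `COc1cc(C(=O)/C=C/c2cc(-c3cc(OC)c(OC)c(OC)c3)n[nH]2)cc(OC)c1OC` has not yet been measured in this assay; it differs from compound 2 by methoxy in place of hydrogen on an aromatic carbon, the same change as the one from compound 3 to compound 1, at the same place. Because the earlier step was a 1.9-fold lower number from compound 3 to compound 1 (0.28 log units; within the scatter), compound 4 is expected to give a step of a 1.7-fold lower number from compound 2 to compound 4 (0.22 log units; within the scatter) in this assay. Compound 4 is therefore estimated at 1000 nM, expected to lie between 450 nM and 2400 nM.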

Compound 4, concentration for 50% growth inhibition: 1570 nM
Compound 4: the middle estimate sits 1.6-fold (0.20 log units) below what was measured; the range from low to high includes it.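

In this assay, methoxy in place of hydrogen on an aromatic carbon gave a 1.1-fold lower number from compound 2 to compound 4 (0.02 log units; within the scatter). Set beside the earlier step, the change behaved alike on the two cores, with no difference that can be told apart: the same change on two cores in this assay, a 1.9-fold lower number (0.28 log units; within the scatter) from compound 3 to compound 1 and a 1.1-fold lower number (0.02 log units; within the scatter) from compound 2 to compound 4, 1.8-fold (0.26 log units) apart, within the scatter of two such steps. Both steps lie within the scatter, so the data do not show that this methoxy measurably alters growth inhibition on either core, nor how it would behave on a third core.

The compounds shown leave open whether a different group at this place, such as a hydroxyl, a fluorine or a longer chain like ethoxy, would give a step beyond the scatter.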